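The compounds below may be only part of what the source reports. "The series", "measured", "known", "first", "only" and "open" are said of these compounds alone.

Measured compounds:
compound 1, `Cc1ccc(-c2cnc(N(Cc3ccccc3)Cc3ccc(C(=O)NO)cc3)s2)cc1`: 34000 nM
compound 2, `CCCCCCN(Cc1ccc(C(=O)NO)cc1)c1ncc(-c2ccc(C)cc2)s1`: 7420 nM

In a functional assay on HepG2 cells (Homo sapiens) for antiproliferative activity, read by MTT assay, with a stated time of 48 h (on this read-out higher numbers stand for weaker inhibition of growth and lower numbers for stronger inhibition of growth), compound 1 gives 34000 nM, the highest of the two numbers; compound 2 gives 7420 nM. Within the data shown here, the single step at this position is a 4.6-fold lower number from compound 1 to compound 2 (0.66 log units; beyond the scatter). Compound 3, `Cc1ccc(-c2cnc(N(CCCOc3ccccc3)Cc3ccc(C(=O)NO)cc3)s2)cc1`, differs from compound 1 by 2-phenoxyethyl in place of phenyl on a saturated chain carbon bound to a nitrogen on an aromatic ring. The entering group still carries a six-membered aromatic ring, so a drop smaller than that to compound 2 is expected, in the same direction. Compound 3 is estimated at 14000 nM, between 6000 nM and 34000 nM. The expected step is a 2.4-fold lower number from compound 1 to compound 3 (0.39 log units; beyond the scatter).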

Compound 3, concentration for 50% growth inhibition: 23400 nM
For compound 3 the middle estimate is 1.7-fold (0.22 log units) below the measured one, within the range that was stated.
By their numbers in this assay, from the lowest: compound 2; then compounds 3 and 1 (each within the scatter of the next).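

In this assay, 2-phenoxyethyl in place of phenyl gives a 1.5-fold lower number from compound 1 to compound 3 (0.16 log units; within the scatter), so lengthening the link to the six-membered aromatic ring leaves compound 3 level with compound 1. Phenoxy in place of propyl gives a 3.2-fold higher number from compound 2 to compound 3 (0.50 log units; beyond the scatter), which sets compound 2, the only one of the three whose chain ends without an aromatic ring, apart from compound 3. No available evidence explains this difference. Open, on these data alone, is how a chain ending in an amine or a carboxylic acid would compare. A longer unbranched alkyl chain also remains to be placed against compound 2.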